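1H-tetrazol-5-yl in place of cyano on compound 2

The compounds below may be only part of what the source reports. "The series", "measured", "known", "first", "only" and "open" are said of these compounds alone.

In a physicochemical assay for solubility (a higher number here means a more soluble compound, a lower number a less soluble compound), compound 1 (`O=C(O)c1ccc(S(=O)(=O)N2CCC(NS(=O)(=O)c3cc(S(=O)(=O)c4ccccc4)ccc3C(F)(F)F)CC2)cc1`) gives 12500 nM and compound 2 (`N#Cc1cccc(S(=O)(=O)N2CCC(NS(=O)(=O)c3cc(S(=O)(=O)c4ccccc4)ccc3C(F)(F)F)CC2)c1`) gives 6300 nM on the shared core. These two numbers lie within the scatter of each other, so compound 2 holds no distinct place in this small set.

The change to compound 3 (`O=S(=O)(NC1CCN(S(=O)(=O)c2cccc(-c3nnn[nH]3)c2)CC1)c1cc(S(=O)(=O)c2ccccc2)ccc1C(F)(F)F`) is 1H-tetrazol-5-yl in place of cyano on an aromatic carbon with 1H-tetrazol-5-yl in place of cyano on an aromatic carbon, meta to a large group. Among the compounds with values here, one measured step bears on it, a 2.0-fold lower number from compound 1 to compound 2 (0.30 log units; within the scatter) with 3-cyanophenyl in place of 4-carboxyphenyl on a sulfonyl sulfur. Within the data shown here, that step stayed within the scatter, and no compound carrying 1H-tetrazol-5-yl has a number yet, so the evidence is thin.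

A modest upward step in this assay is expected, and none beyond the scatter is foreseen. The expected change is a 1.6-fold higher number from compound 2 to compound 3 (0.20 log units; within the scatter) and this remains an estimate. Compound 3 is expected at 10000 nM (estimated range 4000 nM to 25000 nM).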

Compound 3, solubility: 100000 nM
Estimate against measurement, compound 3: 10-fold (1.00 log units) below; measured number above the stated range.
By their numbers in this assay, from the lowest: compounds 2 and 1 (each within the scatter of the next); then compound 3.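

In this assay the exchange of cyano for 1H-tetrazol-5-yl on this aromatic carbon, meta to a large group, gives a 16-fold higher number from compound 2 to compound 3 (1.20 log units; beyond the scatter) and thereby shows that the number responds to the group at this position, whereas the earlier step between the first two compounds stayed within the scatter. The 3-(1H-tetrazol-5-yl)phenyl group also separates from 4-carboxyphenyl on the sulfonyl sulfur, with an 8.0-fold higher number from compound 1 to compound 3 (0.90 log units; beyond the scatter) and compound 3 therefore stands highest of the three, its steps to both others being beyond the scatter. No accompanying measurement accounts for the size of this rise.

As far as these compounds go, the finding rests on a single compound carrying 1H-tetrazol-5-yl, so it remains open whether a step of this size belongs to this group alone or would recur on a different core. From the compounds shown here alone, how a primary amide or an amine on the same aromatic carbon would read in this assay also remains open, and so does whether either would come close to compound 3 on the shared core.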